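The compounds below may be only part of what the source reports. "The series", "measured", "known", "first", "only" and "open" are said of these compounds alone.

Measured so far in a functional assay on DU-145 cells (Homo sapiens) for inhibition, read by CCK-8 assay, with a stated time of 72 h; a higher number here means a weaker inhibitor, a lower number a stronger inhibitor:
- compound 1 `O=C(/C=C/c1cccnc1)NCCCCCCCc1ccc(S(=O)(=O)Nc2ccccc2)cc1`: 438 nM
- compound 2 `O=C(/C=C/c1cccnc1)NCCCCCCCc1cccc(S(=O)(=O)Nc2ccccc2)c1`: 429 nM
- compound 3 `Cc1ccccc1NS(=O)(=O)c1cccc(CCCCCCNC(=O)/C=C/c2cccnc2)c1`: 2.9 nM

Compound 1 and compound 2 lie within the usual scatter of each other. Compound 3 has the lowest number of the three, and it is the strongest inhibitor in this assay, with a gap well beyond the scatter to both of the others. It differs from each of them in more than one place, so these values do not isolate any single change.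

Compound 4 `CC(C)(C)c1ccc(NS(=O)(=O)c2cccc(CCCCCCNC(=O)/C=C/c3cccnc3)c2)cc1` keeps the rest of compound 3 but carries 4-(tert-butyl)phenyl in place of 2-methylphenyl on a sulfonamide nitrogen. Going by the values given here, no measured compound carries this new group, so the expectation is a cautious one. Compound 3, at 2.9 nM, sits so low that there seems more room for the number to rise than to fall. The expected step is a 6.9-fold higher number from compound 3 to compound 4 (0.84 log units; beyond the scatter), a moderate weakening beyond the scatter. For compound 4 the estimated value is 20 nM, with an expected range of 3 nM to 150 nM.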

Compound 4, half-maximal inhibitory concentration: 281 nM
Compound 4: middle estimate off by 14-fold (1.15 log units), on the low side; the whole stated range lies below it.
By their numbers in this assay, from the lowest: compound 3; then compounds 4, 2 and 1 (each within the scatter of the next).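

Going by these compounds alone, replacing 2-methylphenyl with 4-(tert-butyl)phenyl on the sulfonamide nitrogen is the first single change in this set, and in this assay it gives a 97-fold higher number from compound 3 to compound 4 (1.99 log units; beyond the scatter). The aromatic ring stays and the swap adds only carbon, yet the number still moves well beyond the scatter, so this position does not accept every carbon-only aryl group equally. No measurement here explains the loss.

The swap removes the methyl group and brings in a tert-butyl group at a different place on the ring, so the compounds shown cannot separate the effect of the group from that of its place. Going by these compounds, how the number would respond to a fluorine atom, a methoxy group or an amine on that ring remains open.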